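The source may hold more compounds than are shown below. What is called first, only, known or untested is meant among the compounds shown, and "the series" means these compounds.

Compound 1 `CCN1CCN(c2cc(C)c3cc(NC(=O)c4ccc(F)cc4)ccc3n2)CC1` and compound 2 `CCN1CCN(c2cc(C)c3cc(NC(=O)c4ccccc4C)ccc3n2)CC1` share one core and differ only in the aromatic group attached to the carbonyl carbon of the amide. In a functional assay on MCF7 cells (Homo sapiens) for antiproliferative activity, read by MTT assay, with a stated time of 72 h (a lower number here means a stronger inhibitor, a higher number a weaker inhibitor), compound 1 gives 4030 nM, and compound 2 gives 10900 nM. Among the compounds with values here, the one measured step, a 2.7-fold higher number from compound 1 to compound 2 (0.43 log units; beyond the scatter), shows that this exchange weakened inhibition. Among the two numbers available, compound 2 stands highest; its only neighbour is compound 1, whose number is lower by that same step.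

Compound 3 `CCN1CCN(c2cc(C)c3cc(NC(=O)c4ccc(F)c(F)c4)ccc3n2)CC1` has not yet been measured. It is reached from compound 2 by one change: 3,4-difluorophenyl in place of 2-methylphenyl on a carbonyl carbon. Within the data shown here, the only step that bears on this is a 2.7-fold higher number from compound 1 to compound 2 (0.43 log units; beyond the scatter), which replaced 4-fluorophenyl with 2-methylphenyl; compound 3 goes the other way, carrying 3,4-difluorophenyl, which resembles the 4-fluorophenyl of compound 1 far more than the 2-methylphenyl of compound 2. The expected movement is therefore back toward the number of compound 1, so the step of a 2.4-fold lower number from compound 2 to compound 3 (0.38 log units; beyond the scatter) is expected to be a modest lowering, beyond the scatter. For compound 3 the estimate in this assay is 4500 nM, with a range from 2000 nM to 11000 nM.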

Compound 3, half-maximal inhibitory concentration: 5230 nM
Compound 3: middle estimate off by 1.2-fold (0.07 log units), on the low side; measured number inside the range.
By their numbers in this assay, from the lowest: compounds 1 and 3 (each within the scatter of the next); then compound 2.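

In this assay, the swap of 2-methylphenyl for 3,4-difluorophenyl on the carbonyl carbon gives a 2.1-fold lower number from compound 2 to compound 3 (0.32 log units; beyond the scatter) and shows that the weaker number of compound 2 does not extend to every aromatic group at this place, since both fluorinated phenyl groups now give lower numbers than 2-methylphenyl. Going from the 4-fluorophenyl of compound 1 to the 3,4-difluorophenyl of compound 3 places fluoro in place of hydrogen on an aromatic carbon, and a 1.3-fold higher number from compound 1 to compound 3 (0.11 log units; within the scatter) means this second fluoro brings no change that can be told apart from ordinary assay scatter. No measurement at hand explains any of these differences.

Within the data shown here, with only three aromatic groups in view, it remains open whether the methyl group itself or its place on the ring separates compound 2 from the others, which a plain phenyl and a 4-methylphenyl would help settle. As far as these compounds go, how a methoxy group, an amine or a carboxylic acid on this ring would fare also stays open.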